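A Much Longer Chain on a Shared Core

The source may report more compounds than this note shows. Statements on the series, on what has been measured and on what is new or still open speak of the compounds shown alone.

In a functional assay on the whole organism with Mus musculus as the target, in the rotarod test (a higher number here means that more compound is needed for the effect, a lower number that less compound is needed), compound 1 (`CCC(=O)NCC(=O)N(C)c1ccc(Cl)cc1C(=O)c1ccccc1Cl`) gives 36 mg/kg as its measured dose, and compound 2 (`CCCCCCC(=O)NCC(=O)N(C)c1ccc(Cl)cc1C(=O)c1ccccc1Cl`) gives 70 mg/kg on the same scale, which places the two within the scatter of each other. Compound 3 (`CCCCCCCCCCCCCCCC(=O)NCC(=O)N(C)c1ccc(Cl)cc1C(=O)c1ccccc1Cl`) has not yet been measured. It keeps the core of compound 2 and differs from it by one change on the chain: nonyl in place of hydrogen on a saturated chain carbon, six bonds along the chain from a carbonyl carbon is the whole difference. Going by the values given here, only one measured step bears on this change. Butyl in place of hydrogen on the same chain gave a 1.9-fold higher number from compound 1 to compound 2 (0.29 log units; within the scatter) in the data. Among the compounds with values here, that single step stays inside the scatter, so it is weak guidance, and no measured compound carries a chain as long as that of compound 3. Resting on a 1.9-fold higher number from compound 1 to compound 2 (0.29 log units; within the scatter) alone, a modest move toward a higher number in this assay is expected, with wide uncertainty. The expected change is a 1.9-fold higher number from compound 2 to compound 3 (0.27 log units; within the scatter) in this estimate. For compound 3 the estimated dose is 130 mg/kg within an expected range of 50 mg/kg to 400 mg/kg for the coming measurement.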

Compound 3, dose for half-maximal effect: > 100 mg/kg
Compound 3 was reported as a limit (the forecaster's own chance of this, stated with the estimate: 20%); the middle value is on the limit's open side.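

In this assay, going by these compounds alone, compound 3 gives > 100 mg/kg, which is a limit of the assay and not a number, and it is the only limit among the values shown: the limit of > 100 mg/kg in this assay, at which 1 of the 3 values shown sits. The nonyl group in place of hydrogen, on a saturated chain carbon six bonds along the chain from a carbonyl carbon, gives an at least 1.4-fold higher number from compound 2 to compound 3 (0.15 log units; that floor lies within the scatter), so only a floor is known for this step and its full size remains unfixed. The earlier compounds offered only a butyl step at this chain, a 1.9-fold higher number from compound 1 to compound 2 (0.29 log units; within the scatter), whereas this result adds that even the much longer chain of compound 3 gives no sign of a return to a lower number, although neither step is shown to lie beyond the scatter.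

The compounds shown leave open where the actual number for compound 3 lies, and so whether this long chain truly separates it from compound 2 in this test. They also leave open how a pentyl group, a shorter chain than nonyl, would read at this place, and whether an amine or a carboxylic acid carried on the chain would give a lower number.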